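Tert-Butyl in Place of Iodo on the Outer Phenoxy Ring

This account rests on a few compounds, and the source may have more. Where it says the series, first, only, none or still open, it means among the compounds named here.

Of the compounds shown here, three sharing one core have been measured in an assay on cells for agonist activity at probable G-protein coupled receptor 34 (Mus musculus), with a stated time of 1 h; on this read-out lower numbers stand for smaller maximal responses and higher numbers for larger maximal responses. Compound 1 `N[C@@H](COP(=O)(O)OCCCOC(=O)CCc1ccccc1OCc1cccc(Oc2ccccc2)c1)C(=O)O` gives 19.4%. Compound 2 `N[C@@H](COP(=O)(O)OCCCOC(=O)CCc1ccccc1OCc1cccc(Oc2ccc(Cl)cc2)c1)C(=O)O` gives 17.8%. Compound 3 `N[C@@H](COP(=O)(O)OCCCOC(=O)CCc1ccccc1OCc1cccc(Oc2ccc(I)cc2)c1)C(=O)O` gives 19.1%, the second highest of the three numbers; it lies a number 0.3 percentage points lower from compound 1 to compound 3 (within the scatter) and a number 1.3 percentage points higher from compound 2 to compound 3 (within the scatter), so all three stand as one group within the scatter.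

Compound 4 `CC(C)(C)c1ccc(Oc2cccc(COc3ccccc3CCC(=O)OCCCOP(=O)(O)OC[C@H](N)C(=O)O)c2)cc1` has not yet been measured. It differs from compound 3 by tert-butyl in place of iodo on an aromatic carbon. The measured steps that bear on this change are the ones at the same aromatic carbon: a number 1.6 percentage points lower from compound 1 to compound 2 (within the scatter), a number 0.3 percentage points lower from compound 1 to compound 3 (within the scatter) and a number 1.3 percentage points higher from compound 2 to compound 3 (within the scatter). Each of these stayed within the scatter, so across hydrogen, chloro and iodo on that carbon the maximal response did not move. Nothing measured shows what a tert-butyl group does at this position, and the three compounds give no reason to expect a step beyond the scatter in either direction. Compound 4 is therefore estimated at 19%, with a range from 10% to 28%. The expected step is accordingly a number 0.1 percentage points lower from compound 3 to compound 4 (within the scatter), within the scatter.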

Compound 4, largest response reached (Emax), in percent of the reference or control that the assay uses: 16.9%
For compound 4 the middle estimate is 2.1 percentage points above the measured one, and the stated range covers the measured number.
By their numbers in this assay, from the lowest: compounds 4, 2, 3 and 1 (each within the scatter of the next).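

Until compound 4, this aromatic carbon had carried only hydrogen, chloro and iodo, and the tert-butyl group now extends the series to a substituent of 4 heavy atoms in place of the single atom of iodo. In this assay, this larger group still leaves the maximal response within the scatter of all three earlier compounds (a number 2.2 percentage points lower from compound 3 to compound 4 (within the scatter); a number 0.9 percentage points lower from compound 2 to compound 4 (within the scatter); a number 2.5 percentage points lower from compound 1 to compound 4 (within the scatter)), so the four compounds stand as one group and this position has so far tolerated every group placed on it without a change that can be read. Nothing available explains why the read-out stays level across these groups.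

Iodo and tert-butyl both count 0 hydrogen-bond donors, 0 hydrogen-bond acceptors and no net charge, so it remains open whether an amine or a carboxylic acid on this same aromatic carbon would move the maximal response beyond the scatter. The compounds shown also leave open whether a longer chain at this carbon, or a change elsewhere on the shared core, would lift the response in this assay out of the range these four share.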